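A few compounds are considered here, and "the series" means these few. Any claim that something is new, unique, unknown or untested is made for them only; others in the source may bear on it.

Compound 1 `Cn1c(=O)c2[nH]c(-c3ccc(S(=O)(=O)N4CCN(Cc5ccc(Br)cc5)CC4)cc3)cc2n(C)c1=O` — 1 nM in an assay on HEK293 cells for displacement of a labelled ligand from adenosine receptor A2b (Homo sapiens); a lower number here means a stronger inhibitor, a higher number a weaker inhibitor
Compound 2 `Cn1c(=O)c2[nH]c(-c3ccc(S(=O)(=O)N4CCN(Cc5ccc(F)cc5)CC4)cc3)cc2n(C)c1=O` — 10 nM in this assay
Compound 3 `CCCn1c(=O)n(C)c(=O)c2[nH]c(-c3ccc(S(=O)(=O)N4CCN(Cc5cccc(F)c5)CC4)cc3)cc21` — 17 nM in this assay

Among these three compounds, compound 1 gives the lowest number in this assay; the nearest of the others is compound 2, and the furthest is compound 3, whose value lies beyond the scatter from that of compound 1. Going by the values given here, the one step that can be read directly is a 10-fold higher number from compound 1 to compound 2 (1.00 log units; beyond the scatter), which shows that even a small change on the aromatic ring attached to the piperazine moves the number noticeably.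

Compound 4 `Cn1c(=O)c2[nH]c(-c3ccc(S(=O)(=O)N4CCN(c5ccccc5)CC4)cc3)cc2n(C)c1=O` differs from compound 1 as follows: phenyl in place of 4-bromobenzyl on an amine nitrogen in a ring. Among the compounds with values here, no measured pair covers this change; the only step that bears on it is a 10-fold higher number from compound 1 to compound 2 (1.00 log units; beyond the scatter), and it involved a far smaller change at the same end of the molecule. Since that small change already cost potency in this assay, a larger loss is expected from compound 1 to compound 4, estimated at a 15-fold higher number from compound 1 to compound 4 (1.18 log units; beyond the scatter). Compound 4 is therefore expected to give about 15 nM in this assay, with a likely range from 3 nM to 80 nM.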

Compound 4, half-maximal inhibitory concentration: 6 nM
Compound 4: the middle estimate sits 2.5-fold (0.40 log units) above what was measured; the measured number falls inside the stated range.
By their numbers in this assay, from the lowest: compound 1; then compounds 4, 2 and 3 (each within the scatter of the next, the first and the last beyond it).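

In this assay the step from 4-bromobenzyl to phenyl on the ring nitrogen gives a 6.0-fold higher number from compound 1 to compound 4 (0.78 log units; beyond the scatter) and thus shows that this position still carries a low number when the aromatic ring stands directly on the nitrogen, with no benzyl carbon. Against the fluorinated analogue the change gives a 1.7-fold lower number from compound 2 to compound 4 (0.22 log units; within the scatter) and so phenyl and 4-fluorobenzyl cannot be told apart here, while compound 1 alone stands clear of both. No measurement at hand explains this result.

On these data alone, the step from compound 1 to compound 4 removes the bromine and the benzyl carbon together, so the share of each remains open. An unsubstituted benzyl, a 4-bromophenyl or a longer chain such as 2-phenylethyl at this nitrogen would separate them.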